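From Vinyl to 2-Chloro-1,3-thiazol-5-yl on the Amide Carbonyl

The source may report more compounds than this note shows. Statements on the series, on what has been measured and on what is new or still open speak of the compounds shown alone.

In an ADME assay on HepG2 cells (Homo sapiens) for inhibition, with a stated time of 72 h (a lower number here means that less compound is needed, a higher number that more compound is needed for the effect), compound 1 `C=CC(=O)Nc1cccc(-c2nc3ccccc3s2)c1` gives > 25000 nM, which is a limit of the assay rather than a number. Compound 2 `CN(C)CCC(=O)Nc1cccc(-c2nc3ccccc3s2)c1` gives 21000 nM. Compound 3 `O=C(Nc1cccc(-c2nc3ccccc3s2)c1)c1ccnc(Cl)c1` gives > 25000 nM, again a limit of the assay. Compound 1 therefore stands at the limit of > 25000 nM in this assay, at which 2 of the 3 values shown sit. The step of an at least 1.1-fold lower number from compound 1 to compound 2 (0.07 log units; that floor lies within the scatter) and the step of an at least 1.1-fold higher number from compound 2 to compound 3 (0.07 log units; that floor lies within the scatter) are the only readable ones, and both lie within the scatter; the step that the two limits leave unreadable from compound 1 to compound 3. Compound 4 `O=C(Nc1cccc(-c2nc3ccccc3s2)c1)c1cnc(Cl)s1` differs from compound 1 by 2-chloro-1,3-thiazol-5-yl in place of vinyl on a carbonyl carbon. The three variations on the amide carbonyl of the shared core have all left this assay at or near its limit, so no step beyond the scatter is expected here. Compound 4 is estimated at 30000 nM, between 12000 nM and 80000 nM, an expected step that the limit leaves unreadable from compound 1 to compound 4.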

Compound 4, half-maximal effective concentration: > 25000 nM
Compound 4 gave a limit, no number (the forecaster's own chance of this, stated with the estimate: 70%); the middle value does not contradict the limit.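

Compound 4 adds a five-membered aromatic ring to this position, and this assay still returns only a limit, as it does for the six-membered ring of compound 3. Most values at this position now sit at that limit: the limit of > 25000 nM in this assay, at which 3 of the 4 values shown sit. For the compounds shown here, the one readable new step is an at least 1.1-fold higher number from compound 2 to compound 4 (0.07 log units; that floor lies within the scatter), and the steps from compound 1 and compound 3 to compound 4 cannot be read.

Going by these compounds, how far these limits lie from the true values remains open. So does whether a group such as a carboxylic acid or a longer amine chain on this carbonyl carbon would give a clearly lower number.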